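The compounds below may be only part of what the source reports. "The series", "measured", "known", "first", "only" and "open" are said of these compounds alone.

Compound 2 `CCCCCn1c(N)nc2c(OC)cccc21` is a small molecule built on a shared core, and in an assay on HEK293 cells for agonist activity at Toll-like receptor 8 (Homo sapiens), read by reporter gene assay (a lower number here means that less compound is needed, a higher number that more compound is needed for the effect), compound 2 gives 3740 nM. Compound 1 `CCCCCCn1c(N)nc2ccccc21` gives 3960 nM in this assay, and the two values lie within the usual scatter of each other, so compound 2 cannot be set apart from compound 1. Compound 3 `CCCCCn1c(N)nc2c(OCc3ccccc3)cccc21` is reported in this assay as "not active" (no number reported), with no number given. Compound 4 `CCCCCn1c(N)nc2c(N)cccc21` differs from compound 2 in one place: amino in place of methoxy on an aromatic carbon. For the measured compounds named here, no measured pair shows what this swap does, so its size is uncertain; a step in this assay no larger than the usual scatter is expected, if anything toward a lower number. Compound 4 is therefore estimated at 2800 nM, within a range from 900 nM to 9000 nM, which means an expected step of a 1.3-fold lower number from compound 2 to compound 4 (0.13 log units; within the scatter).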

Compound 4, half-maximal effective concentration: 6600 nM
The estimate for compound 4 lay 2.4-fold (0.37 log units) below the measured number; the range from low to high includes it.
By their numbers in this assay, from the lowest: compounds 2, 1 and 4 (each within the scatter of the next).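

In this assay amino in place of methoxy on this aromatic carbon, ortho to a fused ring and meta to a fused ring, gives a 1.8-fold higher number from compound 2 to compound 4 (0.25 log units; within the scatter) and so cannot be told apart from no change. For the compounds shown here, this is the first measured swap at this position, and compound 4 still gives a number with amino there. No measurement at hand bears on what lies behind this result. From the compounds shown here alone, whether a hydroxyl or a chlorine at the same position would give a step beyond the scatter stays open.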